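The compounds below may be only part of what the source reports. "The series", "measured", "known", "first", "only" and "open" are said of these compounds alone.

For the measured compounds named here, compound 2 `Nc1ncnc2c1nc(NCc1cccc(Cl)c1)n2[C@@H]1O[C@H](CO)[C@@H](O)[C@H]1O` is the only compound with a number here: in an assay on COS-7 cells for inhibition of sodium/nucleoside cotransporter 2 (Homo sapiens), read by scintillation counting, in the presence of a further agent that is not named here (on this read-out lower numbers stand for stronger inhibition and higher numbers for weaker inhibition), compound 2 gives 5400 nM. Compound 1 `COc1ccccc1CNc1nc2c(N)ncnc2n1[C@@H]1O[C@H](CO)[C@@H](O)[C@H]1O` reaches only a limit of the assay, as in this assay compound 1 gives > 100000 nM. Going by the values given here, the single measured step, an at least 18-fold lower number from compound 1 to compound 2 (1.26 log units; beyond the scatter), came with 3-chlorophenyl in place of 2-methoxyphenyl on a saturated chain carbon bound to a nitrogen on an aromatic ring. Compound 3 `COc1cccc(CNc2nc3c(N)ncnc3n2[C@@H]2O[C@H](CO)[C@@H](O)[C@H]2O)c1` differs from compound 2 by methoxy in place of chloro on an aromatic carbon. That measured step changed the group and its place at once, so it does not isolate this exchange of chloro for methoxy. A modest step toward a weaker number is expected, a 2.2-fold higher number from compound 2 to compound 3 (0.35 log units; beyond the scatter). Compound 3 is therefore estimated at 12000 nM, within a range from 2500 nM to 60000 nM.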

Compound 3, half-maximal inhibitory concentration: 13000 nM
Compound 3: the middle estimate sits 1.1-fold (0.03 log units) below what was measured, and the stated range covers the measured number.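

Compound 3 separates the two changes that the first step mixed. With the place on the ring held, methoxy in place of chloro costs only a modest amount: a 2.4-fold higher number from compound 2 to compound 3 (0.38 log units; beyond the scatter). With methoxy held, the 3-methoxyphenyl group in place of the 2-methoxyphenyl group gives a clearly larger gain, an at least 7.6-fold lower number from compound 1 to compound 3 (0.88 log units; beyond the scatter), so where the group sits matters at least as much here as which group it is, though this step rests on a limit for compound 1: the limit of > 100000 nM in this assay, at which 1 of the 3 values shown sits.

As far as these compounds go, whether an amine or a nitrile in that same place would give a lower number than compound 2 remains open. So does the effect of a longer chain in place of the 3-chlorobenzyl group.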